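The source may report more compounds than this note shows. Statements on the series, on what has been measured and on what is new or still open speak of the compounds shown alone.

Measured in a functional assay on MDA-MB-231 cells (Homo sapiens) for cytotoxicity, read by MTT assay, with a stated time of 72 h; a higher number here means a weaker inhibitor, a lower number a stronger inhibitor:
Compound 1 `COc1ccc(NC(=O)CN2CCN(c3nnc(Cc4ccncc4)c4ccccc34)CC2)cc1OC`: 100 nM
Compound 2 `O=C(CN1CCN(c2nnc(Cc3ccncc3)c3ccccc23)CC1)Nc1cccc(Br)c1`: 1.7 nM

Of these two numbers, compound 2 holds the lower, at 1.7 nM. Compound 3 `O=C(CN1CCN(c2nnc(Cc3ccncc3)c3ccccc23)CC1)Nc1ccc(Br)cc1` keeps the shared core and differs from compound 2 in a single change, 4-bromophenyl in place of 3-bromophenyl on an amide-type nitrogen. Within the data shown here, only one measured step bears on this place, a 59-fold lower number from compound 1 to compound 2 (1.77 log units; beyond the scatter), where 3-bromophenyl replaced 3,4-dimethoxyphenyl. Among the measured compounds shown here, that large step shows this assay responding to a change on this nitrogen, but no measured pair compares bromophenyl isomers. A step of that size is therefore not expected here. Since compound 2 already stands low at 1.7 nM, a modest move toward a higher number seems likelier than a further drop. The expected change is a 2.9-fold higher number from compound 2 to compound 3 (0.47 log units; beyond the scatter). Compound 3 is estimated at 5 nM, with an expected range from 1 nM to 30 nM.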

Compound 3, half-maximal inhibitory concentration: 19 nM
Compound 3: the middle estimate sits 3.8-fold (0.58 log units) below what was measured; low and high end bracket the measured number.
By their numbers in this assay, from the lowest: compound 2; then compound 3; then compound 1.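

In this assay the place of the bromine on the phenyl group matters: 4-bromophenyl in place of 3-bromophenyl on the amide-type nitrogen gives an 11-fold higher number from compound 2 to compound 3 (1.05 log units; beyond the scatter) with the same atoms simply joined differently. The earlier step exchanged 3,4-dimethoxyphenyl for 3-bromophenyl and so could not separate the presence of bromine from its place on the ring. With 4-bromophenyl there is still a 5.3-fold lower number from compound 1 to compound 3 (0.72 log units; beyond the scatter) in favour of the bromo compound, so part of the earlier gain remains, though less than with 3-bromophenyl.

Nothing measured here accounts for the gap between the two bromophenyl isomers. As far as these compounds go, it remains open whether 3-chlorophenyl or a phenyl group carrying a carboxylic acid on this nitrogen would follow the same order.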